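The source may report more compounds than this note shows. Statements on the series, on what has been measured and on what is new or still open speak of the compounds shown alone.

Values in a functional assay on A2780 ADR cells (Homo sapiens) for cytotoxicity, read by MTT assay, with a stated time of 24 h; a higher number here means a weaker inhibitor, a lower number a stronger inhibitor:
- compound 1 `CCCCC[C@@H](C[C@H](O)C[C@@H]1CC=CC(=O)O1)OC`: 26300 nM
- compound 2 `CCCCC[C@@H](C[C@@H](O)C[C@@H]1CC=CC(=O)O1)OC`: 46300 nM

Within the data shown here, compound 2 lies within the scatter of compound 1, the only other measured compound. Compound 3 `CCCCC[C@H](C[C@H](O)C[C@@H]1CC=CC(=O)O1)OC` is unmeasured. Its difference is the two compounds have the same atoms and bonds and differ only in configuration as drawn: 2 of 3 stereo elements differ; a stereocentre at a saturated chain carbon is drawn S in compound 2 and R in compound 3; a stereocentre at a saturated chain carbon is drawn R in compound 2 and S in compound 3.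

Among the measured compounds shown here, one measured step bears on this change: a 1.8-fold higher number from compound 1 to compound 2 (0.25 log units; within the scatter). That step involved a single stereo element, and a change at two has not been measured. No step beyond the scatter is therefore expected in this assay, though this rests on thin evidence. The expected step is a 1.3-fold lower number from compound 2 to compound 3 (0.12 log units; within the scatter). The estimate for compound 3 is 35000 nM, with an expected range of 14000 nM to 85000 nM.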

Compound 3, half-maximal inhibitory concentration: 30000 nM
Beside the measured number, compound 3's estimate is 1.2-fold (0.07 log units) above it; measured number inside the range.
By their numbers in this assay, from the lowest: compounds 1, 3 and 2 (each within the scatter of the next).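

In this assay, a change at two chain stereocentres at once gives a 1.5-fold lower number from compound 2 to compound 3 (0.19 log units; within the scatter), so a double inversion also stays within the scatter. A change at only one of these centres gives a 1.1-fold higher number from compound 1 to compound 3 (0.06 log units; within the scatter), which adds a second single-centre step to the earlier one, at a different chain carbon and again within the scatter. Neither chain stereocentre separates the three compounds in this assay.

From the compounds shown here alone, the fourth arrangement of these two centres remains open. So does whether an amine, a carboxylic acid or a longer chain on the shared core would move the number beyond the scatter.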